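Methyl in Place of Hydrogen on an Acetoxyethyl Chain

The compounds below may be only part of what the source reports. "The series", "measured", "known", "first", "only" and "open" are said of these compounds alone.

Measured in a functional assay on MCF7 cells (Homo sapiens) for inhibition, read by XTT assay, with a stated time of 48 h; on this read-out lower numbers stand for stronger inhibition and higher numbers for weaker inhibition:
compound 1, `COc1ccc(C(=O)/C(=C/C2CCCCC2)CCOC(C)=O)cc1`, gives > 100000 nM, a limit of the assay.
compound 2, `COc1ccc(C(=O)/C(=C/c2c(F)c(F)c(F)c(F)c2F)CCOC(C)=O)cc1`, gives > 100000 nM, a limit of the assay.
compound 3, `COc1ccc(C(=O)/C(=C/C2CCCCC2)CC(C)OC(C)=O)cc1`, gives > 100000 nM, a limit of the assay.

Compound 4, `COc1ccc(C(=O)/C(=C/c2c(F)c(F)c(F)c(F)c2F)CC(C)OC(C)=O)cc1`, is not yet measured. It differs from compound 2 by methyl in place of hydrogen on a saturated chain carbon bound to an oxygen next to a carbonyl group and a saturated chain carbon. The same change separates compound 1 from compound 3, (methyl in place of hydrogen on a saturated chain carbon bound to an oxygen next to a carbonyl group and a saturated chain carbon), and there the step in this assay is a step that the two limits leave unreadable from compound 1 to compound 3. The difference between the two cores, that of compound 1 and that of compound 2, is not broken down here. All that can be said of the measured set is given by the limit of > 100000 nM in this assay, at which 3 of the 3 values shown sit.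

For compound 4 the step from compound 2 is expected to be a step that the limit leaves unreadable from compound 2 to compound 4, an expectation that rests on compound 3 sitting at > 100000 nM after the same change from compound 1. Compound 4 is therefore estimated at 150000 nM, most likely reported only as a limit, within a range from 50000 nM to 500000 nM.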

Compound 4, half-maximal inhibitory concentration: > 100000 nM
Compound 4 was reported as a limit (the forecaster's own chance of this, stated with the estimate: 85%); the middle value does not contradict the limit.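

In this assay, compound 2 and compound 4 are both reported only as limits, and no step can be read between them. The compounds shown leave open how strongly any of them inhibits and whether methyl in place of hydrogen on this chain changes inhibition at all, with every result resting on one value: the limit of > 100000 nM in this assay, at which 4 of the 4 values shown sit.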